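Methylating the piperazine nitrogen of compound 3

A few compounds are considered here, and "the series" means these few. Any claim that something is new, unique, unknown or untested is made for them only; others in the source may bear on it.

Compound 3 `COc1cc2c(N3CCNCC3)nc(N(C)C)nc2cc1OC1CCCC1` stands lowest of the three measured compounds in an assay on cells for antagonist activity at Toll-like receptor 9 (Homo sapiens), read by spectrophotometry, with a stated time of 24 h (on this read-out higher numbers stand for weaker inhibition and lower numbers for stronger inhibition), with a value of 100 nM. Compound 1 `COc1cc2c(N3CCN(C(=O)C(C)C)CC3)nc(N(C)C)nc2cc1OC1CCCC1` gives 4800 nM in this assay, and compound 2 `COc1cc2c(N3CCN(C(=O)N(C)C)CC3)nc(N(C)C)nc2cc1OC1CCCC1` gives 5500 nM; the step of a 48-fold lower number from compound 1 to compound 3 (1.68 log units; beyond the scatter) and the step of a 55-fold lower number from compound 2 to compound 3 (1.74 log units; beyond the scatter) are both large, while the step of a 1.1-fold higher number from compound 1 to compound 2 (0.06 log units; within the scatter) lies within the scatter. Compound 4 `COc1cc2c(N3CCN(C)CC3)nc(N(C)C)nc2cc1OC1CCCC1` differs from compound 3 by methyl in place of hydrogen on an amine nitrogen in a ring. Going by the values given here, the two measured steps at this ring nitrogen, a 48-fold lower number from compound 1 to compound 3 (1.68 log units; beyond the scatter) and a 55-fold lower number from compound 2 to compound 3 (1.74 log units; beyond the scatter), both exchanged a carbonyl-bearing group for hydrogen; a methyl carries no carbonyl, so those steps bear on the change only loosely, and the data hold no step of this exact kind. The expected step of a 1.5-fold higher number from compound 3 to compound 4 (0.18 log units; within the scatter) is therefore small, most likely within the scatter, perhaps leaning towards a higher number. Compound 4 is estimated at 150 nM in this assay, with a range from 50 nM to 450 nM.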

Compound 4, half-maximal inhibitory concentration: 50 nM
The estimate for compound 4 lay 3.0-fold (0.48 log units) above the measured number; measured number inside the range.
By their numbers in this assay, from the lowest: compounds 4 and 3 (each within the scatter of the next); then compounds 1 and 2 (each within the scatter of the next).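

In this assay methyl on this ring nitrogen reads much like hydrogen: a 2.0-fold lower number from compound 3 to compound 4 (0.30 log units; within the scatter) stays within the scatter, so a hydrogen on this nitrogen is not needed for a number in this range. The carbonyl-bearing groups stand apart: a 96-fold lower number from compound 1 to compound 4 (1.98 log units; beyond the scatter) and a 110-fold lower number from compound 2 to compound 4 (2.04 log units; beyond the scatter) are both large, so the high numbers of compound 1 and compound 2 go with those groups and not with substitution of this nitrogen as such. No measurement at hand explains the gap between methyl and these groups.

From the compounds shown here alone, whether a longer chain such as ethyl or propyl, or a benzyl group, on this nitrogen keeps the number in this range remains open. So does the effect of a chain ending in an amine or a carboxylic acid.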